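From nitro to chloro on a shared core

The compounds below may be only part of what the source reports. "The series", "measured", "known", "first", "only" and "open" are said of these compounds alone.

In a functional assay (aorta) with Rattus norvegicus as the target (on this read-out lower numbers stand for an effect already at smaller amounts and higher numbers for an effect only at larger amounts of compound), each measured compound gives only a limit:
Compound 1 `CN(C)/C(=N\C#N)C1=CC(C)(C)Oc2ccc([N+](=O)[O-])cc21` gives > 31600 nM as a limit
Compound 2 `CN(C)/C(=N\C#N)C1=CC(C)(C)Oc2ccc(S(C)(=O)=O)cc21` gives > 31600 nM as a limit
Compound 3 `CN(C)/C(=N\C#N)C1=CC(C)(C)Oc2ccc(Br)cc21` gives > 31600 nM as a limit

Compound 1 stands at the limit of > 31600 nM in this assay, at which 3 of the 3 values shown sit, and so offers no number as a starting point. Compound 4 `CN(C)/C(=N\C#N)C1=CC(C)(C)Oc2ccc(Cl)cc21` keeps the core of compound 1, and the change is chloro in place of nitro on an aromatic carbon on that core. Closest to this is a step that the two limits leave unreadable from compound 1 to compound 3 with bromo in place of nitro on an aromatic carbon. Less direct are a step that the two limits leave unreadable from compound 1 to compound 2 and a step that the two limits leave unreadable from compound 2 to compound 3 among the same compounds. None of these gives a size, so no readable step is expected in this assay in either direction. The estimated step is a step that the limit leaves unreadable from compound 1 to compound 4 and probably stays unreadable. For compound 4 the expected value is 40000 nM with an estimated range from 15000 nM to 100000 nM on this read-out.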

Compound 4, half-maximal effective concentration: > 31600 nM
Compound 4: only a limit was reported (the forecaster's own chance of this, stated with the estimate: 85%); the middle value is on the limit's open side.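

No step can be read between compound 4 and compound 1, compound 2 or compound 3, because all four stop at the same point: the limit of > 31600 nM in this assay, at which 4 of the 4 values shown sit.

The compounds shown leave open where their true values lie and whether any group at this place on the shared core changes the effect.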